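Trimming the Methoxyethyl Ether Where Nothing Binds

This account rests on a few compounds, and the source may have more. Where it says the series, first, only, none or still open, it means among the compounds named here.

Compound 1 `COCCO[C@H]1CC[C@H]2CCN(C)[C@H]2C1` and compound 3 `CN1CC[C@@H]2CC[C@H](O)C[C@@H]21` share one core, while compound 2 `COCCO[C@H]1CC=C2CCN(C)[C@H]2C1` and compound 4 `CN1CCC2=CC[C@H](O)C[C@@H]21` share another. The difference between the two cores is not broken down here.

In an assay on HEK293 cells for displacement of a labelled ligand from Neuronal acetylcholine receptor; alpha4/beta4 (Rattus norvegicus), with a stated time of 4 h (on this read-out lower numbers stand for stronger inhibition and higher numbers for weaker inhibition), compound 1 gives > 300000 nM, which is a limit of the assay and not a number. Compound 3 gives > 300000 nM in this assay, again a limit. Compound 2 also stops at a limit, giving > 300000 nM in this assay. The change from compound 1 to compound 3 is hydrogen in place of 2-methoxyethyl on an oxygen on a saturated carbon and its step is a step that the two limits leave unreadable from compound 1 to compound 3, because the limit of > 300000 nM in this assay, at which 3 of the 3 values shown sit, leaves no room to read how large it was.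

The same change separates compound 2 from compound 4: hydrogen in place of 2-methoxyethyl on an oxygen on a saturated carbon. The two places agree word for word, so it is the same change on a different core. Since compound 2 already sits at the limit in this assay, compound 4 is expected to follow a step that the limit leaves unreadable from compound 2 to compound 4, which in practice means no measurable binding. The estimate for compound 4 in this assay is therefore 500000 nM, between 200000 nM and 3000000 nM.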

Compound 4, inhibition constant: > 300000 nM
Compound 4: only a limit was reported; the forecaster's own chance of this, stated with the estimate: 90%; the middle value does not contradict the limit.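

No size can be read for the change from compound 2 to compound 4, because both compounds stop at a limit and not at a number: the limit of > 300000 nM in this assay, at which 4 of the 4 values shown sit. The compounds shown leave open whether swapping 2-methoxyethyl for hydrogen alters binding at all on either core, since none of them gives a readable value in this assay.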